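A few compounds are considered here, and "the series" means these few. Any claim that something is new, unique, unknown or untested is made for them only; others in the source may bear on it.

Of the compounds shown here, three that share a core have been tested in an ADME assay on cells (Erythrocyte, Homo sapiens), read by spectrophotometry and hemolysis, with a stated time of 24 h; on this read-out higher numbers stand for weaker inhibition and lower numbers for stronger inhibition. Compound 1 `NC(=S)N/N=C/c1ccc(OCc2ccc3no[n+]([O-])c3c2)cc1` gives > 200 uM, which is a limit of the assay and not a number. Among the measured compounds shown here, compound 2 `O=Cc1cccc(OCc2ccc3no[n+]([O-])c3c2)c1` gives 50 uM, the only actual number so far. Compound 3 `O=Cc1ccccc1OCc1ccc2no[n+]([O-])c2c1` gives > 100 uM, which is also a limit and not a number. Compound 3 is therefore known only through that limit, and one other compound is likewise known only through a limit.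

Compound 4 `N=C(N)N/N=C\c1ccccc1OCc1ccc2no[n+]([O-])c2c1` has not yet been measured. It differs from compound 3 as follows: a group of 6 heavy atoms (2 carbon, 4 nitrogen; no ring) in place of a group of 2 heavy atoms (1 carbon, 1 oxygen; no ring), on an aromatic carbon. The new group, which replaces the formyl, sits on an aromatic carbon, ortho to a large group.

For the measured compounds named here, no measured pair differs in one place, so no direct step is available as a guide. The expectation leans on compound 1, whose limit is > 200 uM. In this assay, a small move toward weaker inhibition, probably not beyond the usual scatter, is expected, estimated as a step that the limit leaves unreadable from compound 3 to compound 4. For compound 4, the estimate is 180 uM, with an expected range of 60 uM to 450 uM.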

Compound 4, concentration for 50% inhibition: 58 uM
For compound 4 the middle estimate is 3.1-fold (0.49 log units) above the measured one, outside the stated range (below it).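

In this assay compound 4 gives an actual number at this place on the ring, an aromatic carbon ortho to a large group, where until now there was only a limit. Exchanging the formyl for the open-chain group of 6 heavy atoms (2 carbon, 4 nitrogen) gives an at least 1.7-fold lower number from compound 3 to compound 4 (0.23 log units; that floor lies within the scatter). The true size of this step cannot be read because compound 3 is known only through a limit of the assay and not a number: the limit of > 100 uM in this assay, at which 1 of the 4 values shown sits.

From the compounds shown here alone, it remains open whether a simple amine or a carboxylic acid in the same place would give a higher or lower number. Going by these compounds, it also remains open whether the new group would read the same way on another carbon of that ring.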